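Dimethylamino in place of 1H-imidazol-1-yl: notes on compound 4

The source may hold more compounds than are shown below. What is called first, only, known or untested is meant among the compounds shown, and "the series" means these compounds.

In a functional assay on the whole organism for agonist activity, with Mus musculus as the target (on this read-out lower numbers stand for an effect already at smaller amounts and higher numbers for an effect only at larger amounts of compound), compound 2 `CC(C#CCn1ccnc1)N1CCCC1=O` gives > 100 mg/kg, a limit and not a number. Compound 3 `Cc1cncn1CC#CC(C)N1CCCC1=O` gives > 100 mg/kg, also a limit. Compound 1 `CC(=O)N(C)C(C)C#CCn1ccnc1` gives a true number, 3 mg/kg. Compound 2 therefore stands at the limit of > 100 mg/kg in this assay, at which 2 of the 3 values shown sit.

Compound 4 `CC(C#CCN(C)C)N1CCCC1=O` carries dimethylamino in place of 1H-imidazol-1-yl on a saturated chain carbon bound to a triple-bonded carbon. For the measured compounds named here, the only measured step, methyl in place of hydrogen on an aromatic carbon, is a step that the two limits leave unreadable from compound 2 to compound 3, so it offers no size to carry over. The data do not test this exchange directly, and any expectation is loose. A move towards smaller doses is expected, with an at least 12-fold lower number from compound 2 to compound 4 (1.09 log units; beyond the scatter) as a rough estimate. For compound 4 the estimate is 8 mg/kg, with an expected range of 1 mg/kg to 60 mg/kg.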

Compound 4, dose for half-maximal effect: 6.6 mg/kg
Estimate against measurement, compound 4: 1.2-fold (0.08 log units) above, within the range that was stated.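

In this assay, for the compounds shown here, the saturated chain carbon bound to a triple-bonded carbon is the first place to give a readable change: dimethylamino in place of 1H-imidazol-1-yl gives an at least 15-fold lower number from compound 2 to compound 4 (1.18 log units; beyond the scatter). The step from compound 2 to compound 3 cannot be read, so the ring methyl offered no such information. The size of the new step is only a lower bound, since compound 2 sits at a limit: the limit of > 100 mg/kg in this assay, at which 2 of the 4 values shown sit.

Open, from the compounds shown here alone, is how a cyclic amine such as pyrrolidin-1-yl, or the larger diethylamino, would fare at this place. Also open, going by these compounds, is whether a longer chain would keep the effect.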